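One Carbon More on the Ether Chain of Compound 3

The source may report more compounds than this note shows. Statements on the series, on what has been measured and on what is new or still open speak of the compounds shown alone.

Three compounds share one core and differ only in the saturated chain attached through an oxygen on the aromatic ring. In a functional assay on DLD-1 cells (Homo sapiens) for cytotoxicity, read by MTT assay, with a stated time of 48 h (on this read-out higher numbers stand for weaker inhibition and lower numbers for stronger inhibition), compound 1 `CCCCCCOc1ccc2c(Cl)ccnc2c1` gives 2660 nM. In this assay compound 2 `CC(C)COc1ccc2c(Cl)ccnc2c1` gives 3100 nM. In this assay compound 3 `CCOc1ccc2c(Cl)ccnc2c1` gives 2750 nM. The three numbers sit close together: a 1.2-fold higher number from compound 1 to compound 2 (0.07 log units; within the scatter), a 1.0-fold higher number from compound 1 to compound 3 (0.01 log units; within the scatter) and a 1.1-fold lower number from compound 2 to compound 3 (0.05 log units; within the scatter). For the measured compounds named here, compound 3 thus lies within the scatter of both compound 1 and compound 2, and no compound among the three can be called stronger or weaker than another.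

Compound 4 `CC(C)Oc1ccc2c(Cl)ccnc2c1` differs from compound 3 in one place: methyl in place of hydrogen on a saturated chain carbon bound to an oxygen on an aromatic ring and a saturated chain carbon. Every measured step concerns this same chain, and none of them moved the number beyond the scatter, so the step to compound 4 is expected to stay within the scatter too, in this assay an expected step of a 1.0-fold higher number from compound 3 to compound 4 (0.01 log units; within the scatter). Compound 4 is therefore estimated at 2800 nM, with a range from 1400 nM to 5600 nM.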

Compound 4, half-maximal inhibitory concentration: 3240 nM
Estimate against measurement, compound 4: 1.2-fold (0.06 log units) below; the measured number falls inside the stated range.
By their numbers in this assay, from the lowest: compounds 1, 3, 2 and 4 (each within the scatter of the next).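

The earlier steps shown here changed the length of the chain or its shape further out, whereas this one puts a methyl on a saturated chain carbon bound to an oxygen on an aromatic ring and a saturated chain carbon, turning ethoxy into isopropoxy, and this assay shows a 1.2-fold higher number from compound 3 to compound 4 (0.07 log units; within the scatter). The isopropyl chain also sits level with the isobutyl and hexyl chains, with a 1.0-fold higher number from compound 2 to compound 4 (0.02 log units; within the scatter) and a 1.2-fold higher number from compound 1 to compound 4 (0.09 log units; within the scatter), so this carbon, like the rest of the chain, has so far shown no step beyond the scatter. No measurement offers an explanation for this flat picture.

Going by these compounds, all four chains are plain saturated carbon chains, so whether an amine, a carboxylic acid or a ring on the chain would move the number beyond the scatter stays open. On these data alone, whether a change to the shared core would do so also stays open.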